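A few compounds are considered here, and "the series" means these few. Any claim that something is new, unique, unknown or untested is made for them only; others in the source may bear on it.

Compound 1 `Cc1cc(S(=O)(=O)/N=C(\N)n2nccc2-c2ccccc2)c(SCc2ccccc2)cc1Cl` gives 20000 nM in a functional assay on MCF7 cells (Homo sapiens) for cytotoxicity, read by MTT assay, with a stated time of 72 h; on this read-out lower numbers stand for stronger inhibition and higher numbers for weaker inhibition. Compound 2 `Cc1cc(-c2ccccc2)n(/C(N)=N/S(=O)(=O)c2cc(C)c(Cl)cc2SCc2ccc(C(F)(F)F)cc2)n1` gives 16000 nM. Compound 3 `Cc1cc(-c2ccccc2)n(/C(N)=N/S(=O)(=O)c2cc(C)c(Cl)cc2SCc2ccccc2)n1` gives 15000 nM.

Going by the values given here, compound 3 stands among the three within the scatter: the steps of a 1.3-fold lower number from compound 1 to compound 3 (0.12 log units; within the scatter) and a 1.1-fold lower number from compound 2 to compound 3 (0.03 log units; within the scatter) both fall inside it, so no compound here is set apart from the others.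

Compound 4 `Cc1cc(-c2ccccc2)n(/C(N)=N/S(=O)(=O)c2cc(C)c(Cl)cc2SCc2ccccc2Cl)n1` differs from compound 3 by chloro in place of hydrogen on an aromatic carbon. The two measured steps that bear on this, a 1.3-fold lower number from compound 1 to compound 3 (0.12 log units; within the scatter) and a 1.1-fold lower number from compound 2 to compound 3 (0.03 log units; within the scatter), each swap a substituent on an aromatic carbon and each stayed within the scatter. On that basis no step beyond the scatter is expected in this assay for compound 4. Compound 4 is estimated at 14000 nM, range 6000 nM to 35000 nM, the expected step being a 1.1-fold lower number from compound 3 to compound 4 (0.03 log units; within the scatter).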

Compound 4, half-maximal inhibitory concentration: 135000 nM
Compound 4: middle estimate off by 9.6-fold (0.98 log units), on the low side; measured number above the stated range.
By their numbers in this assay, from the lowest: compounds 3, 2 and 1 (each within the scatter of the next); then compound 4.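

In this assay the 2-chlorobenzyl group gives the first real separation in the series: a 9.0-fold higher number from compound 3 to compound 4 (0.95 log units; beyond the scatter) and an 8.4-fold higher number from compound 2 to compound 4 (0.93 log units; beyond the scatter) lie beyond the scatter, while a 1.1-fold lower number from compound 2 to compound 3 (0.03 log units; within the scatter) stays within it. The ring of the benzylsulfanyl group therefore does not tolerate every substituent equally, and chloro at the place ortho to a large group gives the weaker number. Nothing available here explains this rise. Going by these compounds, whether a fluoro, methyl or methoxy group at that same place would give a similar rise stays open. So does whether chloro there has the same effect on the core of compound 1.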